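From Methylsulfanyl to Amino in an Antiproliferative Series

The source may report more compounds than this note shows. Statements on the series, on what has been measured and on what is new or still open speak of the compounds shown alone.

- Compound 1 `COc1ccc2c(/C=C/C(=O)c3cc(N)c(OC)c(OC)c3)cn(C)c2c1` gives 505 nM
- Compound 2 `COc1cc(C(=O)/C=C/c2cn(C)c3ccccc23)cc(SC)c1OC` gives 102 nM

Both numbers come from a functional assay on MCF7 cells (Homo sapiens) for antiproliferative activity, read by MTT assay, with a stated time of 48 h (a lower number here means a stronger inhibitor, a higher number a weaker inhibitor), and are the only two available. Compound 2 has the lower number, and its gap to compound 1 lies beyond the usual scatter of repeated measurements. Compound 3 `COc1cc(C(=O)/C=C/c2cn(C)c3ccccc23)cc(N)c1OC` has amino in place of methylsulfanyl on an aromatic carbon of compound 2, ortho to a methoxy group (amino in place of methylsulfanyl on an aromatic carbon). For the measured compounds named here, no measured pair shows this change alone. Going by the values given here, the only clue is compound 1 with 505 nM in this assay. Compound 1 also carries an amino group, though it differs from compound 3 elsewhere too. A higher number, meaning a weaker inhibitor, is therefore expected, with a 2.2-fold higher number from compound 2 to compound 3 (0.33 log units; beyond the scatter) as the estimated step, slightly beyond the scatter. The estimate for compound 3 is 220 nM and the expected range runs from 70 nM to 700 nM.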

Compound 3, half-maximal inhibitory concentration: 631 nM
Beside the measured number, compound 3's estimate is 2.9-fold (0.46 log units) below it; measured number inside the range.
By their numbers in this assay, from the lowest: compound 2; then compounds 1 and 3 (each within the scatter of the next).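

In this assay, for the compounds shown here, the pair of compound 2 and compound 3 isolates this change for the first time: amino in place of methylsulfanyl on an aromatic carbon, ortho to a methoxy group, gives a 6.2-fold higher number from compound 2 to compound 3 (0.79 log units; beyond the scatter) and leaves the amino compound the weaker inhibitor of the two. The two amino compounds differ by one further methoxy group, replaced by hydrogen, and show a 1.2-fold higher number from compound 1 to compound 3 (0.10 log units; within the scatter) in this comparison. Nothing measured here explains why the change at this position matters.

The compounds shown hold only methylsulfanyl and amino at this position, so it stays open where a hydroxyl group, a chlorine atom or a longer chain such as ethylsulfanyl would fall. Also open, going by these compounds, is whether methylsulfanyl would give the same gain on the core of compound 1.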